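Shortening the chain: from compound 3 to compound 4

The source may hold more compounds than are shown below. What is called first, only, known or untested is meant among the compounds shown, and "the series" means these compounds.

Working notes on a short series sharing one core. Compound 1 `CCCCC/C=C/CCCCCCCCCC1(C(=O)OC)CO1` gives 680 nM in an assay on isolated protein (Rattus norvegicus) for inhibition of carnitine palmitoyltransferase 1A (Sus scrofa); a lower number here means a stronger inhibitor, a higher number a weaker inhibitor. Compound 2 `CCCCCCC1(C(=O)OC)CO1` gives 136000 nM in this assay, and compound 3 `CCCCCCCCCCCC1(C(=O)OC)CO1` gives 1160 nM. Compound 3 holds the second highest of the three numbers; its nearest neighbour is compound 1, the gap a 1.7-fold higher number from compound 1 to compound 3 (0.23 log units; within the scatter) lying within the scatter, while compound 2 is furthest, the step of a 120-fold lower number from compound 2 to compound 3 (2.07 log units; beyond the scatter) being large and beyond the scatter. Compound 4 `CCCCCCCCCCC1(C(=O)OC)CO1` differs from compound 3 by hydrogen in place of methyl on a saturated chain carbon, ten or more bonds along the chain from a saturated ring carbon. Going by the values given here, two measured steps bear on this. The step in which pentyl replaces hydrogen, a 120-fold lower number from compound 2 to compound 3 (2.07 log units; beyond the scatter), shows that chain length matters strongly. The step in which ethyl replaces hept-1-en-1-yl, a 1.7-fold higher number from compound 1 to compound 3 (0.23 log units; within the scatter), also alters the chain yet stays within the scatter. Loss of a single methyl is a far smaller change than the pentyl step, so only a modest rise in the number, near the edge of the scatter, is expected: a 1.7-fold higher number from compound 3 to compound 4 (0.24 log units; within the scatter). Compound 4 is estimated at 2000 nM, with a range from 1000 nM to 4500 nM.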

Compound 4, half-maximal inhibitory concentration: 680 nM
Compound 4: the middle estimate sits 2.9-fold (0.47 log units) above what was measured; measured number outside the range, below it.
By their numbers in this assay, from the lowest: compounds 1, 4 and 3 (each within the scatter of the next); then compound 2.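

Hydrogen in place of methyl stays within the scatter in this assay (a 1.7-fold lower number from compound 3 to compound 4 (0.23 log units; within the scatter)), so this methyl can be lost without a readable penalty, and the step from the hept-1-en-1-yl chain to methyl likewise shows no difference (no change at the digits printed from compound 1 to compound 4 (within the scatter)). The large gain from the short chain is already present with butyl in place of hydrogen (a 200-fold lower number from compound 2 to compound 4 (2.30 log units; beyond the scatter)), so among these compounds neither the extra methyl of compound 3 nor the longer unsaturated chain of compound 1 is needed to reach this level. No measurement shown offers an explanation for these readings.

On these data alone, the chain lengths between those of compound 2 and compound 4 remain open, so where the large change arises is unknown. Also open, as far as these compounds go, is whether a longer saturated chain, or a hydroxyl, carboxylic acid or amine at this position, would hold the number.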